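The source may hold more compounds than are shown below. What is called first, only, known or untested is meant among the compounds shown, and "the series" means these compounds.

Measured in a functional assay on SMMC-7721 cells (Homo sapiens) for antiproliferative activity, read by CCK-8 assay, with a stated time of 72 h; a higher number here means a weaker inhibitor, a lower number a stronger inhibitor:
- compound 1 `CCc1ccc(SCc2ccc(C(=O)Nc3ccccc3N)cc2)cc1`: 1750 nM
- compound 2 `Cc1ccc(SCc2ccc(C(=O)Nc3ccccc3N)cc2)cc1`: 3740 nM

Among the measured compounds shown here, compound 2 holds the higher of the two numbers, 3740 nM, and compound 1 is its only neighbour. The next compound, compound 3 `Nc1ccccc1NC(=O)c1ccc(CSCCc2ccccc2)cc1`, differs from compound 2 at the sulfur: phenethyl in place of 4-methylphenyl on a sulfur. For the measured compounds named here, only one measured step bears on this change, a 2.1-fold higher number from compound 1 to compound 2 (0.33 log units; beyond the scatter). It is modest, and it also concerns the group on the sulfur. That step alters only a small substituent, however, and the data contain no measured replacement of the whole 4-methylphenyl group. Its direction therefore cannot be carried over with confidence, and no step beyond the scatter is expected in this assay. The expected change is a 1.2-fold lower number from compound 2 to compound 3 (0.10 log units; within the scatter). For compound 3 the estimated value is 3000 nM, with an expected range of 1000 nM to 9000 nM.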

Compound 3, half-maximal inhibitory concentration: 4880 nM
Estimate against measurement, compound 3: 1.6-fold (0.21 log units) below, within the range that was stated.
By their numbers in this assay, from the lowest: compound 1; then compounds 2 and 3 (each within the scatter of the next).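

Among the compounds shown here, compound 3 is the first case in which the whole 4-methylphenyl group on the sulfur is replaced rather than a small substituent on it, and in this assay phenethyl gives a 1.3-fold higher number from compound 2 to compound 3 (0.12 log units; within the scatter) and so cannot be told apart from 4-methylphenyl here. Measured against 4-ethylphenyl, the same replacement gives a 2.8-fold higher number from compound 1 to compound 3 (0.45 log units; beyond the scatter) and thus a clear difference. Compound 1 therefore keeps the lowest number of the three, with its steps to the other two compounds beyond the scatter, while the group on the sulfur tolerates a change from 4-methylphenyl to phenethyl without a readable shift.

No available evidence accounts for the gap between compound 1 and the other two compounds.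

As far as these compounds go, whether an amine or a carboxylic acid on the aromatic ring of phenethyl, or a longer chain on the sulfur, would bring the number closer to that of compound 1 remains open.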